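An Allyl Amide and Its Butyl Counterpart

The source may hold more compounds than are shown below. What is called first, only, known or untested is meant among the compounds shown, and "the series" means these compounds.

In an ADME assay on SJ-G2 cells (Homo sapiens) for cytotoxicity, read by MTT assay, with a stated time of 72 h (on this read-out higher numbers stand for weaker inhibition of growth and lower numbers for stronger inhibition of growth), compound 1 (`CCCCCCCCCCNC(=O)C1C(C(=O)O)[C@@H]2CC[C@H]1O2`) gives 10000 nM and compound 2 (`Cc1cc(C)c(NC(=O)C2C(C(=O)O)[C@@H]3CC[C@H]2O3)c(C)c1`) gives 10000 nM as well. Compound 3 (`C=CCNC(=O)C1C(C(=O)O)[C@@H]2CC[C@H]1O2`) stands level with both (10000 nM) and no gap beyond the scatter separates the three. Compound 4 (`CCCCNC(=O)C1C(C(=O)O)[C@@H]2CC[C@H]1O2`) carries one change from compound 3 (propyl in place of vinyl on a saturated chain carbon bound to an amide-type nitrogen) with propyl in place of vinyl on a saturated chain carbon bound to an amide-type nitrogen. For the measured compounds named here, no measured pair differing in one place is available to size such a change, but compound 1 (10000 nM) and compound 3 (10000 nM) show no gap. The expected step (no change at the digits printed from compound 3 to compound 4 (within the scatter)) in this assay is therefore none beyond the scatter, in either direction. For compound 4 the estimate is expected to fall at the same level (10000 nM) with an estimated range (5000 nM to 20000 nM) around it.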

Compound 4, concentration for 50% growth inhibition: 10000 nM
For compound 4 middle estimate and measured number coincide at the digits printed; measured number inside the range.
By their numbers in this assay, from the lowest: compounds 1, 2, 3 and 4 (each within the scatter of the next).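

In this assay, the first measured pair differing in one place gives no change at the digits printed from compound 3 to compound 4 (within the scatter), so propyl in place of vinyl on a saturated chain carbon bound to an amide-type nitrogen leaves the read-out level. A second pair gives no change at the digits printed from compound 1 to compound 4 (within the scatter), so hydrogen in place of hexyl on a saturated chain carbon, four bonds along the chain from an amide-type nitrogen, also moves nothing beyond the scatter. No evidence bears on why these values stay level.

As far as these compounds go, what a chain carrying an amine or a hydroxyl group would give stays open. So does whether any group on this amide can move the value from this level at all.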